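Half-life after swapping 2-ethylphenyl for 3,4-dimethoxyphenyl

A few compounds are considered here, and "the series" means these few. Any claim that something is new, unique, unknown or untested is made for them only; others in the source may bear on it.

Measured in an ADME assay on microsomes from liver (Rattus norvegicus) for metabolic stability, read by LC-MS, using NADPH, at 37 degrees C; a higher number here means that the compound lasts longer, a lower number that the compound disappears faster:
- compound 1 `Cc1oc(-c2c(Br)cccc2Br)nc1CN1CCC(C(=O)NCCCN2C[C@H](C)C[C@H](C)C2)CC1`: 0.035 h
- compound 2 `Cc1oc(-c2c(Cl)cccc2C(F)(F)F)nc1CN1CCC(C(=O)NCCCN2C[C@H](C)C[C@H](C)C2)CC1`: 0.03 h
- compound 3 `CCc1ccccc1-c1nc(CN2CCC(C(=O)NCCCN3C[C@H](C)C[C@H](C)C3)CC2)c(C)o1`: 0.283 h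

Of the three, compound 3 stands highest at 0.283 h. Compound 4 `COc1ccc(-c2nc(CN3CCC(C(=O)NCCCN4C[C@H](C)C[C@H](C)C4)CC3)c(C)o2)cc1OC` differs from it as follows: 3,4-dimethoxyphenyl in place of 2-ethylphenyl on an aromatic carbon. In words, 3,4-dimethoxyphenyl replaces 2-ethylphenyl on an aromatic carbon. Changes at this place gave an 8.1-fold higher number from compound 1 to compound 3 (0.91 log units; beyond the scatter) and a 9.4-fold higher number from compound 2 to compound 3 (0.97 log units; beyond the scatter), both beyond the scatter, whereas a 1.2-fold lower number from compound 1 to compound 2 (0.07 log units; within the scatter) stayed within it. Going by the values given here, no measured compound carries 3,4-dimethoxyphenyl, so the forecast is uncertain. A move toward the lower values in this assay is expected, of somewhat smaller size than those two larger steps. The estimated change is a 3.1-fold lower number from compound 3 to compound 4 (0.50 log units; beyond the scatter). For compound 4 the expected half-life is 0.09 h, within an estimated range of 0.03 h to 0.28 h.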

Compound 4, half-life: > 0.5 h
Compound 4 ended at the assay's limit; the forecaster's own chance of this, stated with the estimate: 5%; middle value at least 5.5-fold (0.74 log units) away from the limit.
By their numbers in this assay, from the lowest: compounds 2 and 1 (each within the scatter of the next); then compound 3. At a limit, above all of these: compound 4.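

Compound 4 sits at a limit of this assay: the limit of > 0.5 h in this assay, at which 1 of the 4 values shown sits. Against the two halogen-bearing groups the change is large, with an at least 16-fold higher number from compound 2 to compound 4 (1.22 log units; beyond the scatter) and an at least 14-fold higher number from compound 1 to compound 4 (1.15 log units; beyond the scatter), so this position also accepts a phenyl ring carrying two methoxy groups and no ethyl group without the short half-lives seen earlier. Against 2-ethylphenyl, an at least 1.7-fold higher number from compound 3 to compound 4 (0.24 log units; that floor lies within the scatter) gives only a floor, so the size of that gain stays unknown.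

The compounds shown leave open whether a single methoxy group would serve as well here. They also leave open what a pyridine ring in place of the phenyl ring would do.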